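Trimethoxyphenyl triazoles: a para methylsulfanyl replaces meta fluorine

The compounds below may be only part of what the source reports. "The series", "measured", "known", "first", "only" and "open" are said of these compounds alone.

Of the compounds shown here, two have been measured in a functional assay on A549 cells (Homo sapiens) for antiproliferative activity, read by MTT assay, with a stated time of 72 h (on this read-out higher numbers stand for weaker inhibition and lower numbers for stronger inhibition), and neither gave a number. Compound 1 `COc1cc(-c2ncnn2-c2cccc(N)c2)cc(OC)c1OC` is reported only as a limit of this assay, > 10000 nM. Compound 2 `COc1cc(-n2ncnc2-c2cccc(F)c2)cc(OC)c1OC` likewise reaches only a limit of this assay, > 10000 nM. So compound 2 stands at the limit of the assay together with the other value shown (the limit of > 10000 nM in this assay, at which 2 of the 2 values shown sit), and no measured step between related compounds is available.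

Compound 3 `COc1cc(-n2ncnc2-c2ccc(SC)cc2)cc(OC)c1OC` differs from compound 2 in one place: 4-(methylsulfanyl)phenyl in place of 3-fluorophenyl on an aromatic carbon. Among the compounds with values here, with both known values sitting at a limit, there is no step to lean on, and the expectation rests on the size and nature of the change alone. The step from compound 2 to compound 3 is expected to be an at least 3.3-fold lower number from compound 2 to compound 3 (0.52 log units; beyond the scatter), in the direction of stronger inhibition, though with wide uncertainty. Compound 3 is therefore estimated at 3000 nM in this assay, within a range from 300 nM to 20000 nM, with a real chance that it too returns only a limit.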

Compound 3, half-maximal inhibitory concentration: 800 nM
Beside the measured number, compound 3's estimate is 3.8-fold (0.57 log units) above it; the measured number falls inside the stated range.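

Within the data shown here, this is the first value that is a number rather than a limit, so it shows that the aromatic carbon of the five-membered aromatic ring with 3 nitrogen can carry a group that gives a measurable result in this assay. Placing 4-(methylsulfanyl)phenyl there in place of 3-fluorophenyl gives an at least 12-fold lower number from compound 2 to compound 3 (1.09 log units; beyond the scatter), a large step. That size is only a floor, because compound 2 sits at a limit of the assay: the limit of > 10000 nM in this assay, at which 2 of the 3 values shown sit.

The change alters both the substituent and its place on the phenyl ring, so the compounds shown do not tell which of the two carries the gain; 4-fluorophenyl and 3-(methylsulfanyl)phenyl would separate them. Also open, on these data alone, is how much the group can vary, that is, whether 4-methoxyphenyl, 4-(ethylsulfanyl)phenyl or 4-aminophenyl would match compound 3 at 800 nM.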